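Benzyl in place of methyl on the amide of compound 3

The compounds below may be only part of what the source reports. "The series", "measured", "known", "first", "only" and "open" are said of these compounds alone.

Compound 1 `CNC(=O)c1cc(Oc2cccc(NC(=S)Nc3ccc(Cl)cc3)c2)ccn1` in a functional assay on HCT-116 cells (Homo sapiens) for cytotoxicity, read by MTT assay, with a stated time of 48 h (on this read-out lower numbers stand for stronger inhibition and higher numbers for weaker inhibition), gives 39400 nM.
Compound 2 `CNC(=O)c1cc(Oc2cccc(NC(=S)Nc3ccc(F)c(F)c3)c2)ccn1` in this assay gives 30300 nM.
Compound 3 `CNC(=O)c1cc(Oc2cccc(NC(=S)Nc3cccc(C(F)(F)F)c3)c2)ccn1` in this assay gives 25300 nM.

Compound 3 has the lowest of the three numbers, yet every step to it lies within the scatter: a 1.6-fold lower number from compound 1 to compound 3 (0.19 log units; within the scatter) and a 1.2-fold lower number from compound 2 to compound 3 (0.08 log units; within the scatter), with a 1.3-fold lower number from compound 1 to compound 2 (0.11 log units; within the scatter) between the others. All three steps alter only the aryl group on the thiourea. Compound 4 `O=C(NCc1ccccc1)c1cc(Oc2cccc(NC(=S)Nc3cccc(C(F)(F)F)c3)c2)ccn1` differs from compound 3 elsewhere: phenyl in place of hydrogen on a saturated chain carbon bound to an amide-type nitrogen. Within the data shown here, no measured step touches this position, so the three steps give no direct guide, and in this assay an expected step of a 1.2-fold lower number from compound 3 to compound 4 (0.06 log units; within the scatter) is no more than a guess that nothing beyond the scatter will appear. Compound 4 is therefore estimated at 22000 nM, with a range from 6000 nM to 70000 nM.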

Compound 4, half-maximal inhibitory concentration: 7500 nM
Estimate against measurement, compound 4: 2.9-fold (0.47 log units) above, and the stated range covers the measured number.
By their numbers in this assay, from the lowest: compound 4; then compounds 3, 2 and 1 (each within the scatter of the next).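

Benzyl in place of methyl on the amide brings a 3.4-fold lower number from compound 3 to compound 4 (0.53 log units; beyond the scatter) in this assay and so gives the only step shown that lies beyond the scatter, whereas the three changes to the aryl group on the thiourea all stay within it. The read-out therefore responds to this position, and a phenyl on the saturated chain carbon bound to the amide nitrogen is tolerated. Nothing available bears on the reason for this step. The compounds shown leave open whether a longer chain such as phenethyl would lower the number further. They also leave open whether an amine or a carboxylic acid on the phenyl ring would preserve the step.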